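Working notes: an aromatic methoxy change toward compound 3

This account rests on a few compounds, and the source may have more. Where it says the series, first, only, none or still open, it means among the compounds named here.

Measured compounds in a functional assay for inhibition, using microsomes, tested at 200 ug/mL; a higher number here means a weaker effect of the compound at the concentration tested, a lower number a stronger effect:
Compound 1 `CCOC(=O)C1=C(C)N(c2ccccc2)C=CC1c1ccccc1`: -37.1%
Compound 2 `COC(=O)C1=C(C)N(c2ccccc2)C=CC1c1ccccc1`: -37.3%

Among the compounds with values here, the single measured step, a number 0.2 percentage points lower from compound 1 to compound 2 (within the scatter), leaves the read-out unchanged within the scatter. Compound 2 therefore stands alongside compound 1 on the numbers shown: the two values lie within the scatter of each other, and neither can be set above or below the other.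

Compound 3 `COC(=O)C1=C(C)N(c2ccccc2)C=CC1c1ccc(OC)cc1` differs from compound 2 by methoxy in place of hydrogen on an aromatic carbon. Within the data shown here, this change sits on the aromatic ring, where no measured step has yet been made; the only step in hand concerned the saturated chain carbon bound to an oxygen next to a carbonyl group and says nothing about the ring. Among the measured compounds shown here, no measured step bears on the change, so no shift beyond the scatter is expected; the estimated step is a number 0.3 percentage points higher from compound 2 to compound 3 (within the scatter). For compound 3 the expected value in this assay is -37%, with a range from -52% to -22%.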

Compound 3, a percentage reported as activity, at one concentration (the size of the read-out at that concentration, not a potency): -30.3%
Compound 3: middle estimate off by 6.7 percentage points, on the low side; low and high end bracket the measured number.
By their numbers in this assay, from the lowest: compounds 2, 1 and 3 (each within the scatter of the next).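

In this assay, within the data shown here, the change from phenyl to 4-methoxyphenyl gives the first reading on an aromatic ring: a number 7 percentage points higher from compound 2 to compound 3 (within the scatter) is the step. Methoxy, with its 2 heavy atoms, can therefore stand in place of hydrogen on this aromatic carbon, para to a large group, with a step that remains within the scatter in this read-out, so this position now has a measured result that the ester change between the earlier compounds could not provide. Nothing at hand explains the size of this step or connects it to any property of the methoxy group.

From the compounds shown here alone, it remains open what an amine, a carboxylic acid or a longer chain would do on the same aromatic carbon. Going by these compounds, it is equally open whether methoxy would give a similar step on the other phenyl ring of the shared core, or alongside the ethyl ester of compound 1.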